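Swapping the Aryl Group on a Triazole Chalcone Core

The source may hold more compounds than are shown below. What is called first, only, known or untested is meant among the compounds shown, and "the series" means these compounds.

Compound 1 `COc1cc(/C=C/C(C)=O)ccc1OCc1cn(-c2ccccc2OC)nn1`: 2050 nM
Compound 2 `COc1cc(/C=C/C(C)=O)ccc1OCc1cn(-c2ccc(NC(=O)c3ccccc3)cc2)nn1`: 76800 nM

Within the data shown here, in a functional assay on PC-3 cells (Homo sapiens) for antiproliferative activity, read by MTT assay, with a stated time of 48 h (on this read-out lower numbers stand for stronger inhibition and higher numbers for weaker inhibition), compound 1 gives 2050 nM, the lowest of the two numbers; the only other compound, compound 2, gives 76800 nM, a much higher number that lies beyond the scatter. Compound 3 `COc1cc(/C=C/C(C)=O)ccc1OCc1cn(-c2cc(F)cc(Br)c2)nn1` keeps the shared core of compound 1 and differs in one place: 3-bromo-5-fluorophenyl in place of 2-methoxyphenyl on an aromatic nitrogen. Among the measured compounds shown here, no step between measured compounds covers such a change, so the expectation rests on compound 1 alone. Compound 3 is estimated to give 3200 nM, with a range from 800 nM to 13000 nM. The expected step of a 1.6-fold higher number from compound 1 to compound 3 (0.19 log units; within the scatter) is a modest rise, close to the scatter.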

Compound 3, half-maximal inhibitory concentration: 56900 nM
Compound 3: the middle estimate sits 18-fold (1.25 log units) below what was measured, and the stated range ends below it.
By their numbers in this assay, from the lowest: compound 1; then compounds 3 and 2 (each within the scatter of the next).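

In this assay, placing 3-bromo-5-fluorophenyl instead of 2-methoxyphenyl on the aromatic nitrogen gives a 28-fold higher number from compound 1 to compound 3 (1.44 log units; beyond the scatter). The two groups have the same count of heavy atoms, so this position distinguishes between aryl groups of equal heavy-atom count, not merely between small and large substituents. No measurement available here explains the difference. The compounds shown do not separate the part played by the bromine, the fluorine or the departing methoxy group. On these data alone, how a phenyl group carrying an amine or a carboxylic acid would read at this position also remains open.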